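Replacing tert-butoxy with hydrogen in a weak inhibitor

The source may hold more compounds than are shown below. What is called first, only, known or untested is meant among the compounds shown, and "the series" means these compounds.

In a functional assay on PANC-1 cells (Homo sapiens) for inhibition, read by XTT assay, with a stated time of 72 h (on this read-out higher numbers stand for weaker inhibition and lower numbers for stronger inhibition), compound 1 `CC(C)(C)OC(=O)N1CCC[C@H]1COCCCCCCCCC/C=C/c1ccc(-c2ccccc2)cc1` gives 80000 nM, a weak result on a scale where lower numbers mean stronger inhibition. Its close relative, compound 2 `CC(C)(C)OC(=O)N1CCC[C@H]1COCCCCCCCCC/C=C/c1ccc(Oc2ccccc2)cc1`, gives > 100000 nM. From the compounds shown here alone, that value is a limit of the assay and not a number, so the exact standing of compound 2 remains unknown.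

The next structure is compound 3 `O=CN1CCC[C@H]1COCCCCCCCCC/C=C/c1ccc(Oc2ccccc2)cc1`, which keeps the rest of compound 2 but carries hydrogen in place of tert-butoxy on a carbonyl carbon. In effect, tert-butoxycarbonyl becomes formyl.

Within the data shown here, only one measured step is available, an at least 1.2-fold higher number from compound 1 to compound 2 (0.09 log units; that floor lies within the scatter), and it comes from phenoxy in place of phenyl on an aromatic carbon. It does not involve the group changing here, so it offers only weak guidance on size or direction. No step beyond the scatter is therefore expected in this assay, although this expectation is uncertain.

The expected change is a number no higher from compound 2 to compound 3 (the limit leaves the size open).

For compound 3 the estimate is 100000 nM, with an expected range from 40000 nM to 250000 nM.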

Compound 3, half-maximal inhibitory concentration: 63300 nM
For compound 3 the middle estimate is 1.6-fold (0.20 log units) above the measured one; low and high end bracket the measured number.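

Compound 3 is the first of the compounds shown to change at the carbonyl carbon on the amide-type nitrogen in a ring, not on an aromatic carbon. In this assay, going from tert-butoxycarbonyl to formyl gives an at least 1.5-fold lower number from compound 2 to compound 3 (0.19 log units; that floor lies within the scatter). Tert-butoxy is therefore not required for the weak inhibition seen here, since compound 3, with only hydrogen in its place, gives a real number and not a limit, 63300 nM. The true size of the step stays unknown, and it may be larger than its floor, because compound 2 stands at a limit of the assay: the limit of > 100000 nM in this assay, at which 1 of the 3 values shown sits.

From the compounds shown here alone, what remains open is whether other groups at this place, such as an acetyl group or a plain hydrogen on the nitrogen that would leave a free amine, would move the number beyond the scatter. Going by these compounds, it is also open whether formyl would behave the same way on the core of compound 1, which carries phenyl where compound 3 carries phenoxy.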